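Butyl for cyclohexyl on the sulfonylurea nitrogen

A few compounds are considered here, and "the series" means these few. Any claim that something is new, unique, unknown or untested is made for them only; others in the source may bear on it.

Measured compounds:
compound 1 `Cc1cc(C)n(-c2ccc(S(=O)(=O)NC(=O)NNC(=N)N)cc2)n1` 3%
compound 2 `CCNC(=S)NS(=O)(=O)c1ccc(-n2nc(C(=O)O)cc2C)cc1` -2%
compound 3 `Cc1cc(C)n(-c2ccc(S(=O)(=O)NC(=O)NC3CCCCC3)cc2)n1` 10%

The three compounds share a core carrying a sulfonyl group attached to a urea or thiourea nitrogen, and they were examined in a functional assay on the whole organism (blood, strain albino) with Mus musculus as the target, with stated times of 6 days and 4 h, at a dose of 0.4 mmol/kg by the oral route; a higher number here means more inhibition at the dose given (going by the name of the read-out), a lower number less inhibition. Compound 3 has the highest of the three numbers, although the gap to compound 1 is within the scatter, while compound 2 lies beyond the scatter below it. Within the data shown here, only one step among the measured compounds touches the amide-type nitrogen directly: a number 7 percentage points higher from compound 1 to compound 3 (within the scatter), where a cyclohexyl group replaced a guanidine-type substituent without moving the read-out beyond the scatter. Compound 2 differs from compound 3 in more than one place, so its value is noted only as a second low reading.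

The unmeasured compound 4 `CCCCNC(=O)NS(=O)(=O)c1ccc(-n2nc(C)cc2C)cc1` differs from compound 3 by butyl in place of cyclohexyl on an amide-type nitrogen. Among the measured compounds shown here, the only step on this nitrogen, from compound 1 to compound 3, stayed within the scatter despite a larger change in the group, so a change from one carbon-only group to another is expected to give little or no movement. The estimated step of a number 2 percentage points lower from compound 3 to compound 4 (within the scatter) is expected to lie within the scatter. Compound 4 is therefore estimated at 8%, with a range from -4% to 20%.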

Compound 4, a percentage reported as inhibition, in the whole organism at one dose (the size of the read-out at that dose, not a potency): 2%
For compound 4 the middle estimate is 6 percentage points above the measured one; measured number inside the range.
By their numbers in this assay, from the lowest: compounds 2, 4, 1 and 3 (each within the scatter of the next, the first and the last beyond it).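

In this assay, a number 8 percentage points lower from compound 3 to compound 4 (within the scatter) shows that exchanging cyclohexyl for butyl on this amide-type nitrogen, a change between two carbon-only groups that also opens the ring, does not move the read-out beyond the scatter. With a number 1 percentage points lower from compound 1 to compound 4 (within the scatter), where butyl takes the place of the group holding three nitrogens, all the steps among compound 1, compound 3 and compound 4 stay within the scatter, so these three compounds, which differ only at this nitrogen, cannot be separated by this read-out, whether the group there is a carbon ring, an open carbon chain or a nitrogen-rich chain. No supporting data are available that could account for these numbers.

The compounds shown leave open whether any group on this nitrogen can lift the read-out beyond the scatter, for instance a longer chain such as octyl, a phenyl ring, or a butyl chain ending in a carboxylic acid. They also leave open how the carbonyl of the urea compares with the thiocarbonyl of compound 2, which differs from the others in more than one place.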